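The source may hold more compounds than are shown below. What is called first, only, known or untested is meant among the compounds shown, and "the series" means these compounds.

Compound 1 `NC1=NC2(CCOCC2)N(OCCCOc2ccc(Cl)cc2)C(N)=N1`: 33.6 nM
Compound 2 `NC1=NC2(CCOCC2)N(OCCCOc2cccc(Cl)c2Cl)C(N)=N1`: "not determined" (no result reported)
Compound 3 `NC1=NC2(CCOCC2)N(OCCCOc2ccccc2Br)C(N)=N1`: "not determined" (no result reported)

Three compounds of this series were taken into an assay on isolated protein for inhibition of Dihydrofolate reductase (Homo sapiens), read by spectrophotometry, using NADPH, with stated times of 5 s and 6 min; a lower number here means a stronger inhibitor, a higher number a weaker inhibitor. Compound 1 gives 33.6 nM in this assay, and it is the only one of the three with a number: compound 2 was examined but gives only "not determined" (no result reported), and compound 3 likewise gives only "not determined" (no result reported), so compound 1 stands alone as the sole measured point, with nothing to rank it against.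

Compound 4 `CC(C)(C)c1ccc(OCCCON2C(N)=NC(N)=NC23CCOCC3)cc1` keeps the shared core of compound 1 and alters one spot on the aromatic ring at the far end of the linker: tert-butyl in place of chloro on an aromatic carbon. Going by the values given here, no step between two measured compounds is known here, so there is nothing in the data to say how such a change moves the number in this assay. The expectation is therefore modest: compound 4 is expected to come out near compound 1, with a step from a 1.5-fold higher number from compound 1 to compound 4 (0.17 log units; within the scatter) that likely stays within the usual scatter, leaning if anything toward a slightly weaker value. For compound 4 the estimated result in this assay is 50 nM, within a range from 15 nM to 170 nM.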

Compound 4, half-maximal inhibitory concentration: 3.72 nM
Compound 4: the middle estimate sits 13-fold (1.13 log units) above what was measured; the whole stated range lies above it.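

The far end of the molecule clearly matters: on this aromatic carbon, tert-butyl in place of chloro gives a 9.0-fold lower number from compound 1 to compound 4 (0.96 log units; beyond the scatter) in this assay, a step beyond the usual scatter. The position therefore accepts a group of 4 heavy atoms in place of a single chlorine, and here the larger group goes with the stronger inhibitor. Nothing measured here explains the step.

This single pair cannot show whether the number follows the size of the group or something else about tert-butyl, and groups such as methyl, an amine or a carboxylic acid at the same place would be needed to separate these possibilities. From the compounds shown here alone, whether the same change would act alike with a longer chain between the core and the aromatic ring also stays open.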